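A few compounds are considered here, and "the series" means these few. Any claim that something is new, unique, unknown or untested is made for them only; others in the source may bear on it.

Measured compounds:
compound 1 `COc1cc(-c2nnc(SCc3ccc([N+](=O)[O-])cc3)o2)ccc1O` — 14200 nM
compound 2 `COc1cc(-c2nnc(SCc3cccc(Br)c3)o2)ccc1O` — 48100 nM
compound 3 `COc1cc(-c2nnc(SCc3ccccc3F)o2)ccc1O` — 5790 nM

In a functional assay on cells (T-cell, Mus musculus, strain BALB/c) for inhibition, read by MTT assay, with stated times of 24 h and 72 h (on this read-out lower numbers stand for stronger inhibition and higher numbers for weaker inhibition), compound 3 stands lowest of the three numbers. Going by the values given here, compound 1 is nearest to it, and compound 2 furthest, the gap between these two being the single one-place step in the set: an 8.3-fold lower number from compound 2 to compound 3 (0.92 log units; beyond the scatter).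

Compound 4 `COc1cc(-c2nnc(SCc3ccccc3)o2)ccc1O` has not yet been measured in this assay. Its difference from compound 3 is hydrogen in place of fluoro on an aromatic carbon; the fluoro leaves an aromatic carbon of the six-membered ring of carbon only, ortho to a large group, and hydrogen enters there.

No measured step removes a substituent from that ring outright; the one step that bears on the position is the change of aryl group, which moved the number by a modest amount, as shown by the step from compound 2 to compound 3. The numbers of compound 1 and compound 2 show that this ring tolerates changes with effects of modest size, so a small move is plausible, most likely towards a higher number. Compound 4 is therefore expected to give a step of a 1.6-fold higher number from compound 3 to compound 4 (0.19 log units; within the scatter) in this assay. The estimate for compound 4 is 9000 nM, with a range from 4000 nM to 25000 nM.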

Compound 4, half-maximal inhibitory concentration: 1250 nM
For compound 4 the middle estimate is 7.2-fold (0.86 log units) above the measured one; measured number below the stated range.
By their numbers in this assay, from the lowest: compound 4; then compound 3; then compound 1; then compound 2.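

Compound 4, with its plain phenyl, now gives the lowest number of the series in this assay, and its steps to all three substituted compounds lie beyond the scatter (a 4.6-fold lower number from compound 3 to compound 4 (0.67 log units; beyond the scatter); an 11-fold lower number from compound 1 to compound 4 (1.06 log units; beyond the scatter); a 38-fold lower number from compound 2 to compound 4 (1.59 log units; beyond the scatter)). The earlier compounds shown here could only rank fluoro, nitro and bromo against one another, whereas hydrogen now serves as a reference and each of these three groups goes with a higher number, so none of them improves on the unsubstituted ring in this set. Even the loss of a single fluorine, the smallest change here, moves the number beyond the scatter, but no measurement bears on why hydrogen outperforms these groups.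

Fluoro, nitro and bromo differ in both identity and place on the ring, so the effect of the group cannot be separated from that of its position. Going by these compounds, it remains open whether a methoxy group or an amine on this ring, or a longer chain in place of the saturated carbon bound to the sulfur, would match or go below the number of compound 4.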